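The compounds below may be only part of what the source reports. "The series", "measured", "known", "first", "only" and "open" are said of these compounds alone.

Working notes on the series.

Compound 1 `C#CCNC(=O)c1ccc(C(CC)(CC)c2ccc(OCC(=O)C(C)(C)C)c(C)c2)n1CC` carries a propargylamino group on the carbonyl carbon; in an assay on HL-60 cells for agonist activity at vitamin D3 receptor (Homo sapiens), read by microscopy, with a stated time of 96 h (a lower number here means that less compound is needed, a higher number that more compound is needed for the effect), compound 1 gives 2200 nM. Compound 2 `C#CC(C)OC(=O)c1ccc(C(CC)(CC)c2ccc(OCC(=O)C(C)(C)C)c(C)c2)n1CC` differs only in that place and in this assay compound 2 gives 210 nM. For the measured compounds named here, the single measured step, a 10-fold lower number from compound 1 to compound 2 (1.02 log units; beyond the scatter), is the only information on this position. Compound 2 stands with the lowest number of the two, its nearest neighbour being compound 1 with a number higher by that step.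

Compound 3 `CCn1c(C(=O)Nc2cccc(C(F)(F)F)c2)ccc1C(CC)(CC)c1ccc(OCC(=O)C(C)(C)C)c(C)c1` is the next case: (3-(trifluoromethyl)phenyl)amino in place of (1-methylprop-2-yn-1-yl)oxy on a carbonyl carbon. The change returns a hydrogen-bond donor to the carbonyl carbon, as in compound 1, and adds an aromatic ring that neither measured compound has. Going by the values given here, the only step that bears on it is the large one from compound 1 to compound 2, which ran in the opposite sense when an amino group gave way to an oxy group. Going back to an amino group is therefore expected to give a step of a 4.8-fold higher number from compound 2 to compound 3 (0.68 log units; beyond the scatter) towards a higher number in this assay, though the aryl group is untested here and the size is uncertain. For compound 3 the estimate in this assay is 1000 nM, within a range from 200 nM to 6000 nM.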

Compound 3, half-maximal effective concentration: > 50000 nM
Compound 3: no number, only a limit (the forecaster's own chance of this, stated with the estimate: 10%); at least 50-fold (1.69 log units) between middle value and limit.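

In this assay compound 3 gives no number, only a limit of the assay: the limit of > 50000 nM in this assay, at which 1 of the 3 values shown sits. With two amides now in hand, the position proves sensitive to the group on the amide-type nitrogen, and not only to whether an amino or an oxy group sits on the carbonyl carbon: 3-(trifluoromethyl)phenyl in place of propargyl gives an at least 22-fold higher number from compound 1 to compound 3 (1.35 log units; beyond the scatter). Measured against the ester, the change gives an at least 230-fold higher number from compound 2 to compound 3 (2.37 log units; beyond the scatter), so both amino groups shown lie on the higher side of the (1-methylprop-2-yn-1-yl)oxy group, and the aromatic one lies further from it than propargylamino does.

Going by these compounds, it stays open whether the step to compound 3 goes with the aromatic ring or with the trifluoromethyl group, a question that a plain phenylamino group or a benzylamino group on the same carbonyl carbon would address. Also open, on these data alone, is how much of the step from the amide to the ester belongs to the oxygen and how much to the added methyl, which a plain propargyloxy group would separate.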